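A few compounds are considered here, and "the series" means these few. Any claim that something is new, unique, unknown or untested is made for them only; others in the source may bear on it.

Measured compounds:
compound 1, `COc1cc2c(Oc3ccc(NC(=O)Nc4cccc(C)c4)cc3)ccnc2cc1OCCCCCCC(=O)NO`, 1240 nM in a functional assay on MCF7 cells (Homo sapiens) for antiproliferative activity, read by MTT assay; on this read-out higher numbers stand for weaker inhibition and lower numbers for stronger inhibition
compound 2, `COc1cc2c(Oc3ccc(NC(=O)Nc4ccc(C(F)(F)F)cc4Cl)cc3)ccnc2cc1OCCCCCCC(=O)NO`, 500 nM in this assay

Among the two measured compounds, compound 2 has the lowest number in this assay; its nearest neighbour is compound 1, and the gap between them is a 2.5-fold lower number from compound 1 to compound 2 (0.39 log units; beyond the scatter). Among the compounds with values here, that single step is the only measured comparison at this amide-type nitrogen, and it shows that exchanging the group there moves the number by a modest but real amount.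

Compound 3, `COc1cc2c(Oc3ccc(NC(=O)NNC(=O)c4cccc(C)c4)cc3)ccnc2cc1OCCCCCCC(=O)NO`, is not yet measured. It differs from compound 2 in one place: ((3-methylphenyl)carbonyl)amino in place of 2-chloro-4-(trifluoromethyl)phenyl on an amide-type nitrogen. The group that enters carries the 3-methylphenyl motif of compound 1, now held by a carbonyl and an extra nitrogen rather than attached directly. The step from compound 1 to compound 2 bears on this only in that the 3-methylphenyl version gave the higher number; nothing measured shows what the inserted carbonylamino does. The account therefore expects the number for compound 3 to rise by about a 3.0-fold higher number from compound 2 to compound 3 (0.48 log units; beyond the scatter), back toward the level of compound 1 or somewhat beyond it. Compound 3 is estimated at 1500 nM, with a range from 500 nM to 5000 nM.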

Compound 3, half-maximal inhibitory concentration: 5830 nM
For compound 3 the middle estimate is 3.9-fold (0.59 log units) below the measured one; measured number above the stated range.
By their numbers in this assay, from the lowest: compound 2; then compound 1; then compound 3.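

In this assay, the amide-type nitrogen now proves able to move the number much further than the first comparison showed, with a 12-fold higher number from compound 2 to compound 3 (1.07 log units; beyond the scatter). The 3-methylphenyl ring does not keep the level of compound 1 once it is held through a carbonyl and an extra nitrogen, since the change gives a 4.7-fold higher number from compound 1 to compound 3 (0.67 log units; beyond the scatter), so ((3-methylphenyl)carbonyl)amino stands highest of the three groups shown at this place, and the added carbonylamino counts against this read-out whichever of the two directly attached rings it is compared with. Nothing available explains why the number rises with this change.

The compounds shown leave open whether the rise belongs to the carbonyl, to the extra nitrogen or to the two together, and whether it would also appear with 2-chloro-4-(trifluoromethyl)phenyl held through the same carbonylamino. A methylene or a sulfonyl in place of that carbonyl, with the 3-methylphenyl ring kept, would test the first of these questions directly.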